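Aryl for alkyl on the isoxazole: compound 4 estimated

The compounds below may be only part of what the source reports. "The series", "measured", "known", "first", "only" and "open" are said of these compounds alone.

Measured so far:
- compound 1, `CC(=O)OC[C@H]1O[C@@H](n2cc(-c3cn(Cc4ccccc4)nn3)c(=O)[nH]c2=O)C[C@@H]1OC(C)=O`: 99%
- compound 2, `CCCCc1ccc(-c2cc(-c3cn([C@H]4C[C@H](OC(C)=O)[C@@H](COC(C)=O)O4)c(=O)[nH]c3=O)on2)cc1`: 80.5%
- compound 3, `CCCc1cc(-c2cn([C@H]3C[C@H](OC(C)=O)[C@@H](COC(C)=O)O3)c(=O)[nH]c2=O)on1`: 99.5%

In a functional assay on ACHN cells (Homo sapiens) for cytotoxicity, read by sulforhodamine B assay, tested at 10 uM (on this read-out higher numbers stand for more inhibition at the one concentration tested (going by the name of the read-out) and lower numbers for less inhibition), compound 3 gives the highest of the three numbers; compound 1 sits within the scatter of it, and compound 2 lies beyond the scatter below it. Compound 4, `CCc1ccc(-c2cc(-c3cn([C@H]4C[C@H](OC(C)=O)[C@@H](COC(C)=O)O4)c(=O)[nH]c3=O)on2)cc1`, differs from compound 3 by 4-ethylphenyl in place of propyl on an aromatic carbon. Going by the values given here, the one step that bears on this is a number 19 percentage points higher from compound 2 to compound 3 (beyond the scatter), where 4-butylphenyl was traded for propyl. Compound 4 reverses that kind of exchange with a related aryl group, so a drop beyond the scatter is expected, of about a number 14.5 percentage points lower from compound 3 to compound 4 (beyond the scatter). Compound 4 is therefore estimated at 85%, within 70% to 100%.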

Compound 4, a percentage reported as inhibition, at one concentration (the size of the read-out at that concentration, not a potency): 92%
Compound 4: middle estimate off by 7 percentage points, on the low side; low and high end bracket the measured number.
By their numbers in this assay, from the lowest: compound 2; then compounds 4, 1 and 3 (each within the scatter of the next).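

In this assay an aryl group on this carbon, next to the ring nitrogen, holds up about as well as propyl: the change is a number 7.5 percentage points lower from compound 3 to compound 4 (within the scatter) and shows no real loss. Shortening the tail on the aryl group from butyl to ethyl gives a number 11.5 percentage points higher from compound 2 to compound 4 (beyond the scatter) and ties the lower number of compound 2 to the longer tail, not to the aryl ring alone. No measurement here gives a reason for either difference. From the compounds shown here alone, how a phenyl with no tail, or one carrying an amine or a carboxylic acid, would fare remains open.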